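Benzyl in place of trimethylsilylmethyl on compound 2

The source may hold more compounds than are shown below. What is called first, only, known or untested is meant among the compounds shown, and "the series" means these compounds.

Compound 1 `Cc1ncc(CO)c2c(Nc3ccccn3)c(N)oc12` is reported in a functional assay on HEK293 cells for agonist activity at Toll-like receptor 8 (Homo sapiens), read by reporter gene assay (a lower number here means that less compound is needed, a higher number that more compound is needed for the effect), as "not active" (no number reported). Among the measured compounds shown here, compound 2 `Cc1ncc(CO)c2c(Nc3ccccn3)c(NC[Si](C)(C)C)oc12` gives 4990 nM in this assay and is the only compound with a numerical result. Compound 3 `Cc1ncc(CO)c2c(Nc3ccccn3)c(NCc3ccccc3)oc12` differs from compound 2 by a group of 6 heavy atoms (6 carbon; one six-membered aromatic ring of carbon only) in place of a group of 4 heavy atoms (3 carbon, 1 silicon; no ring), on a saturated chain carbon bound to a nitrogen on an aromatic ring. For the measured compounds named here, no step between two measured compounds exists to guide this change, so the step expected from compound 2 to compound 3 is small, at most a modest gain and possibly within the usual scatter: a 1.4-fold lower number from compound 2 to compound 3 (0.15 log units; within the scatter). Compound 3 is expected to give about 3500 nM, with a plausible range from 1000 nM to 12000 nM.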

Compound 3, half-maximal effective concentration: 4910 nM
Compound 3: middle estimate off by 1.4-fold (0.15 log units), on the low side; low and high end bracket the measured number.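

Putting phenyl on a saturated chain carbon bound to a nitrogen on an aromatic ring, in place of the group holding silicon, gives a 1.0-fold lower number from compound 2 to compound 3 (0.01 log units; within the scatter) in this assay. This place therefore takes a six-membered aromatic ring of carbon only as well as a silicon-bearing group with no ring, and the read-out does not separate the two compounds. No measured evidence bears on why they read alike.

Open, on these data alone, is whether a longer chain such as phenethyl, or a terminal amine or carboxylic acid, moves the number beyond the scatter. As far as these compounds go, a small group such as methyl on this nitrogen also remains open.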